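From methoxycarbonyl to carbamoyl: a growth inhibition estimate

The source may hold more compounds than are shown below. What is called first, only, known or untested is meant among the compounds shown, and "the series" means these compounds.

Compound 1 `CNC(=O)/C=C/c1ccncc1-c1ccc2ccccc2c1` gives 6550 nM
Compound 2 `COC(=O)/C=C/c1ccncc1-c1ccc2ccccc2c1` gives 350 nM

In a functional assay on HCT-116 cells (Homo sapiens) for inhibition, read by MTT assay, with a stated time of 72 h (a higher number here means a weaker inhibitor of growth, a lower number a stronger inhibitor of growth), compound 2 has the lower of the two measured numbers, 350 nM against the higher number of compound 1. Compound 3 `NC(=O)/C=C/c1ccncc1-c1ccc2ccccc2c1` keeps the same core but has amino in place of methoxy on a carbonyl carbon. Going by the values given here, one measured step bears on this change: a 19-fold lower number from compound 1 to compound 2 (1.27 log units; beyond the scatter) (methoxy in place of methylamino on a carbonyl carbon). Like compound 1, compound 3 has a nitrogen-linked group on that carbonyl carbon, so a large step towards a higher number is expected. This rests on one step, and amino is not methylamino, so the expected step may be somewhat smaller (an 8.6-fold higher number from compound 2 to compound 3 (0.93 log units; beyond the scatter)). The estimate for compound 3 is 3000 nM (expected range 800 nM to 12000 nM).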

Compound 3, concentration for 50% growth inhibition: 12100 nM
For compound 3 the middle estimate is 4.0-fold (0.61 log units) below the measured one; the whole stated range lies below it.
By their numbers in this assay, from the lowest: compound 2; then compounds 1 and 3 (each within the scatter of the next).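

Removing the methyl from the amide nitrogen does not bring back the lower number of the ester: in this assay the change gives a 35-fold higher number from compound 2 to compound 3 (1.54 log units; beyond the scatter), which is as large a move as the one seen with methylamino. Between the two nitrogen-linked groups there is a 1.8-fold higher number from compound 1 to compound 3 (0.27 log units; within the scatter), so the methyl on that nitrogen makes no difference that can be told from the scatter, and among these three compounds only the methoxy group stands apart. Nothing shown here explains why the ester and the two amides differ.

Going by these compounds, it remains open whether the lower number belongs to methoxy alone or to esters more widely. An ethoxy group, a dimethylamino group or a carboxylic acid on the same carbonyl carbon would help separate these possibilities.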